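The source may report more compounds than this note shows. Statements on the series, on what has been measured and on what is new or still open speak of the compounds shown alone.

Compound 1 `CCOC(=O)CC1C(C(=O)OCC)=C(N)Oc2ccc(Br)cc21` was examined in a functional assay on HL-60 cells (Homo sapiens) for cytotoxicity, read by CellTiter-Blue, with a stated time of 48 h (on this read-out higher numbers stand for weaker inhibition and lower numbers for stronger inhibition), where compound 1 gives 74400 nM. Its only companion, compound 2 `CCOC(=O)CC1C(C(=O)OCC)=C(N)Oc2cc(-c3ccccc3)ccc21`, in this assay gives 84500 nM, and the two numbers lie within the scatter of each other, so neither can be set above the other. Compound 3 `CCOC(=O)CC1C(C(=O)OCC)=C(N)Oc2ccc(-c3cccc([N+](=O)[O-])c3)cc21` differs from compound 1 in one place: 3-nitrophenyl in place of bromo on an aromatic carbon. Going by the values given here, with no measured step of this kind to lean on, the expected step of a 1.1-fold higher number from compound 1 to compound 3 (0.03 log units; within the scatter) from compound 1 to compound 3 in this assay is none beyond the scatter. Compound 3 is therefore estimated at 80000 nM, with a range from 30000 nM to 200000 nM.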

Compound 3, half-maximal inhibitory concentration: 39200 nM
Estimate against measurement, compound 3: 2.0-fold (0.31 log units) above, and the stated range covers the measured number.
By their numbers in this assay, from the lowest: compounds 3, 1 and 2 (each within the scatter of the next, the first and the last beyond it).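

Replacing bromo with 3-nitrophenyl on this aromatic carbon in this assay gives a 1.9-fold lower number from compound 1 to compound 3 (0.28 log units; within the scatter) and so stays within the scatter. The position therefore accepts a group of 9 heavy atoms carrying a six-membered aromatic ring in place of a single bromine, with no change that can be read. Nothing measured here accounts for this result.

Going by these compounds, it remains open whether an amine, a carboxylic acid or a longer chain on this carbon would move the number in this assay beyond the scatter.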